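Swapping a Trifluoromethyl for an Isopropyl Group

This account rests on a few compounds, and the source may have more. Where it says the series, first, only, none or still open, it means among the compounds named here.

Of the compounds shown here, two have so far been measured in a functional assay on A549 cells (Homo sapiens) for inhibition; on this read-out lower numbers stand for stronger inhibition and higher numbers for weaker inhibition. Compound 1 `O=C1C=CC(OCC(F)(F)F)N1c1cc(Cl)cc(Cl)c1` gives 1630 nM. Compound 2 `O=C1C=CC(OCC(F)(F)F)N1c1ccc(C(F)(F)F)cc1` gives 8390 nM, the higher of the two numbers, so it is the weaker inhibitor of the pair. Compound 3 `CC(C)c1ccc(N2C(=O)C=CC2OCC(F)(F)F)cc1` differs from compound 2 in one place: isopropyl in place of trifluoromethyl on an aromatic carbon. Within the data shown here, no measured pair shows this change, so its effect is unknown from these data. The expected step of a 1.4-fold lower number from compound 2 to compound 3 (0.15 log units; within the scatter) is none beyond the usual scatter of repeated measurements. Compound 3 is therefore estimated in this assay at 6000 nM, with a range from 1500 nM to 25000 nM.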

Compound 3, half-maximal inhibitory concentration: 9570 nM
Beside the measured number, compound 3's estimate is 1.6-fold (0.20 log units) below it, within the range that was stated.
By their numbers in this assay, from the lowest: compound 1; then compounds 2 and 3 (each within the scatter of the next).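

In this assay, isopropyl in place of trifluoromethyl on an aromatic carbon, para to a large group, gives a 1.1-fold higher number from compound 2 to compound 3 (0.06 log units; within the scatter) and so no change that can be told from repeated measurement. At this position, a group of carbon alone and a group carrying fluorine therefore cannot be told apart on this read-out. No supporting measurement is available to explain this match.

As far as these compounds go, whether an amine or a carboxylic acid at this position would shift the number beyond the scatter stays open. So does the effect of a longer alkyl chain here.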